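The compounds below may be only part of what the source reports. "The series", "measured", "known", "first", "only" and "open" are said of these compounds alone.

Compound 1 `CN1C/C(=C\c2cccnc2)C(=O)/C(=C/c2ccccc2F)C1` gives 4470 nM in a functional assay on QGY-7703 cells (Homo sapiens) for cytotoxicity, read by MTT assay, with a stated time of 24 h; a lower number here means a stronger inhibitor, a higher number a weaker inhibitor.
Compound 2 `O=C1/C(=C/c2cccnc2)CNC/C1=C\c1ccccc1F` gives 8890 nM in this assay.
Compound 3 `O=C1/C(=C/c2cccnc2)CN(S(=O)(=O)c2ccc(C(F)(F)F)cc2)C/C1=C\c1ccccc1F` gives 4500 nM in this assay.

Among these three numbers compound 3 stands second highest, with compound 1 at the same number and compound 2 within the scatter of it. Within the data shown here, the only single-place step measured is a 2.0-fold higher number from compound 1 to compound 2 (0.30 log units; within the scatter), which changes the ring nitrogen and does not touch the sulfonyl aryl group. Compound 4 `O=C1/C(=C/c2cccnc2)CN(S(=O)(=O)c2ccc(Br)cc2)C/C1=C\c1ccccc1F` differs from compound 3 by bromo in place of trifluoromethyl on an aromatic carbon. Among the measured compounds shown here, no measured step bears on this change, and the three measured numbers all lie within the scatter of one another, so no step beyond the scatter is expected, no change at the digits printed from compound 3 to compound 4 (within the scatter). Compound 4 is therefore estimated at 4500 nM, within a range of 2000 nM to 10000 nM.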

Compound 4, half-maximal inhibitory concentration: 12800 nM
For compound 4 the middle estimate is 2.8-fold (0.45 log units) below the measured one; the measured number lies above the stated range.
By their numbers in this assay, from the lowest: compounds 1, 3, 2 and 4 (each within the scatter of the next, the first and the last beyond it).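

In this assay, among these compounds, bromo in place of trifluoromethyl on the aromatic carbon gives a 2.8-fold higher number from compound 3 to compound 4 (0.45 log units; beyond the scatter), the first step in this set beyond the scatter, so the group at this place on the sulfonyl aryl ring can shift the number. With (4-bromophenyl)sulfonyl on the ring nitrogen, replacing hydrogen gives a 1.4-fold higher number from compound 2 to compound 4 (0.16 log units; within the scatter), while replacing methyl gives a 2.9-fold higher number from compound 1 to compound 4 (0.46 log units; beyond the scatter). Nothing available here accounts for the step from trifluoromethyl to bromo. Going by these compounds, whether a methoxy group, a nitrile or an amine at this aromatic carbon would give a number nearer that of compound 3 or compound 4 stays open.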